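Chloro in Place of Methyl on a Sulfamoylamino Benzamide

The source may hold more compounds than are shown below. What is called first, only, known or untested is meant among the compounds shown, and "the series" means these compounds.

Compound 1 `CCN1CCCC1CNC(=O)c1cc(N(C)S(=O)(=O)N(C)C)c(Cl)cc1OC` bears a chloro group and a fully methylated sulfamoylamino group; in a functional assay on the whole organism for inhibition, with Mus musculus as the target (on this read-out higher numbers stand for an effect only at larger amounts of compound and lower numbers for an effect already at smaller amounts), compound 1 gives 31.8 mg/kg. Compound 2 `CCN1CCCC1CNC(=O)c1cc(NS(=O)(=O)NC)ccc1OC` carries the (methylsulfamoyl)amino group with hydrogen on the neighbouring aromatic carbon, and in this assay compound 2 reaches only the limit of the assay, > 50 mg/kg. Compound 3 `CCN1CCCC1CNC(=O)c1cc(NS(=O)(=O)NC)c(C)cc1OC` has a methyl on that aromatic carbon, and in this assay compound 3 likewise stops at a limit, > 50 mg/kg. The step that the two limits leave unreadable from compound 2 to compound 3 thus cannot be read. Compound 3 stands at the limit of > 50 mg/kg in this assay, at which 2 of the 3 values shown sit, so no number is available for it. Compound 4 `CCN1CCCC1CNC(=O)c1cc(NS(=O)(=O)NC)c(Cl)cc1OC` is formed by the change (chloro in place of methyl on an aromatic carbon). Within the data shown here, no measured step bears directly on this exchange; the only number, that of compound 1, comes from a compound that also differs in the sulfamoyl group, so it gives no clean guide. The step of a number no higher from compound 3 to compound 4 (the limit leaves the size open) is expected to be small, with a real chance that compound 4 again returns only a limit. Compound 4 is estimated at 50 mg/kg, between 20 mg/kg and 150 mg/kg.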

Compound 4, dose for half-maximal effect: > 50 mg/kg
Compound 4 was reported as a limit (the forecaster's own chance of this, stated with the estimate: 55%); the middle value lies on the limit itself.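

With chloro on the aromatic carbon ortho to the (methylsulfamoyl)amino group, compound 4 also stops at a limit in this assay, > 50 mg/kg, so the steps among compound 2, compound 3 and compound 4 cannot be read. With chloro held in place, putting (methylsulfamoyl)amino in place of (dimethylsulfamoyl)(methyl)amino gives an at least 1.5-fold higher number from compound 1 to compound 4 (0.19 log units; that floor lies within the scatter). Chloro at this position therefore does not bring a value under the limit when it is paired with the (methylsulfamoyl)amino group, and the floor of that step does not separate the two sulfamoyl groups: the limit of > 50 mg/kg in this assay, at which 3 of the 4 values shown sit.

Hydrogen, methyl and chloro at this position remain unranked, and it stays open how far compound 4 truly lies from compound 1. From the compounds shown here alone, it is also open whether a bromo group on this aromatic carbon, or an ethyl on the sulfamoyl nitrogen, would give a number rather than a limit.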